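Allyl for acetyl on the shared core: expected recovery

A few compounds are considered here, and "the series" means these few. Any claim that something is new, unique, unknown or untested is made for them only; others in the source may bear on it.

Within the data shown here, compound 3 `CC(=O)c1cc(C(C)=O)c(OCCCCC#N)cc1O` stands lowest of the three measured members in an assay on isolated protein for inhibition of leukotriene B4 receptor 1 (Homo sapiens), tested at 10 uM (a higher number here means more inhibition at the concentration tested (going by the name of the read-out), a lower number less inhibition), where compound 3 gives 8%. The nearest measured neighbour is compound 2 `CCCCCc1cc(C(C)=O)c(O)cc1OCCCCC#N`, which in this assay gives 31%, and the furthest is compound 1 `CCCc1cc(C(C)=O)c(O)cc1OCCCCC#N`, which gives 84%. Compound 4 `C=CCc1cc(C(C)=O)c(O)cc1OCCCCC#N` is not yet measured; it differs from compound 3 in one place: allyl in place of acetyl on an aromatic carbon.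

Among the measured compounds shown here, two measured steps bear on this change. The step of a number 76 percentage points lower from compound 1 to compound 3 (beyond the scatter) shows acetyl replacing a three-carbon chain on the same aromatic carbon, and the step of a number 23 percentage points lower from compound 2 to compound 3 (beyond the scatter) shows acetyl replacing a five-carbon chain there. Allyl is a three-carbon group, so the change from compound 3 to compound 4 largely reverses the first of these. A large rise is therefore expected, close to undoing the loss seen in a number 76 percentage points lower from compound 1 to compound 3 (beyond the scatter).

For compound 4 the estimate is 72%, with a range from 45% to 90%, the expected step being a number 64 percentage points higher from compound 3 to compound 4 (beyond the scatter).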

Compound 4, a percentage reported as inhibition, at one concentration (the size of the read-out at that concentration, not a potency): 92%
Compound 4: the middle estimate sits 20 percentage points below what was measured, and the stated range ends below it.
By their numbers in this assay, from the lowest: compound 3; then compound 2; then compounds 1 and 4 (each within the scatter of the next).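

In this assay, allyl in place of acetyl on this aromatic carbon gives a number 84 percentage points higher from compound 3 to compound 4 (beyond the scatter); both groups carry a double bond outside aromatic rings, so that feature alone does not separate them, whereas the entering group has no oxygen and no hydrogen-bond acceptor. Vinyl in place of ethyl gives a number 8 percentage points higher from compound 1 to compound 4 (within the scatter), so propyl and allyl cannot be told apart here, while vinyl in place of butyl gives a number 61 percentage points higher from compound 2 to compound 4 (beyond the scatter), setting allyl well clear of pentyl as well. Nothing available explains these steps.

Open, going by these compounds, is how a butyl or a propargyl group on this aromatic carbon would read, and whether a carboxylic acid or an amine at the end of a short chain is accepted there. A read-out at one concentration also leaves the potency of the allyl and propyl compounds unresolved.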